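The source may report more compounds than this note shows. Statements on the series, on what has been measured and on what is new or still open speak of the compounds shown alone.

Compound 1 `CC(C)Sc1nc(C(C)c2c(F)cccc2Cl)cc(=O)[nH]1`: > 75000 nM
Compound 2 `CCCSc1nc(C(C)c2c(F)cccc2Cl)cc(=O)[nH]1`: > 75000 nM
Compound 3 `CCc1c(C(C)c2c(F)cccc2F)nc(SC(C)C)[nH]c1=O`: > 3000 nM

In an ADME assay on MT4 cells (Homo sapiens) for activation, read by MTT assay (a lower number here means that less compound is tolerated, a higher number that more compound is tolerated), compound 1 gives > 75000 nM, which is a limit of the assay and not a number. Compound 2 likewise gives > 75000 nM, again a limit. The change between them, (propyl in place of isopropyl on a sulfur), is therefore recorded as a step that the two limits leave unreadable from compound 1 to compound 2. In this assay compound 3 gives > 3000 nM, once more only a limit. Compound 4 `CCCSc1nc(C(C)c2c(F)cccc2F)c(CC)c(=O)[nH]1` has not yet been measured in this assay. It differs from compound 3 by propyl in place of isopropyl on a sulfur, the same change as that made from compound 1 to compound 2, at a place described in identical words; the difference between the core of compound 1 and the core of compound 3 is not broken down here. The expected step is a step that the limit leaves unreadable from compound 3 to compound 4, resting on the limit of > 75000 nM in this assay, at which 2 of the 3 values shown sit, and (the limit of > 3000 nM in this assay, at which 1 of the 3 values shown sits). Compound 4 is accordingly estimated at 80000 nM, between 20000 nM and 300000 nM, most likely reported as a limit.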

Compound 4, half-maximal cytotoxic concentration: > 3000 nM
Compound 4: only a limit was reported; the forecaster's own chance of this, stated with the estimate: 85%; the middle value does not contradict the limit.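

Among these compounds, compound 3 and compound 4 both stand only as limits of the assay, and no step between them can be read. The compounds shown leave open whether propyl in place of isopropyl on a sulfur shifts the half-maximal cytotoxic concentration at all, on either core.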